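The source may report more compounds than this note shows. Statements on the series, on what has been measured and on what is new or still open speak of the compounds shown alone.

Of the compounds shown here, three have been tested so far in a functional assay on the whole organism with Scenedesmus acutus as the target, read by spectrophotometry; a lower number here means a stronger inhibitor, a higher number a weaker inhibitor. In it, compound 1 (`O=c1c2c(sn1-c1ccc(C(F)(F)F)cc1)CCCC2`) gives 55000 nM and compound 3 (`CC(C)OC(=O)c1cc(-n2c(=O)c3c([s+]2[O-])CCCC3)ccc1Cl`) gives 50100 nM, two values within the scatter of each other. Compound 2 (`O=C1C2=C(CCCC2)S(=O)(=O)N1c1ccc(Cl)cc1`) gives 5250 nM, a clearly lower number than either, which makes it the stronger inhibitor of the three.

The next compound changes one group of compound 1. Compound 4 (`O=c1c2c(sn1-c1ccc(Cl)cc1)CCCC2`) has chloro in place of trifluoromethyl on an aromatic carbon, para to a large group: chloro in place of trifluoromethyl on an aromatic carbon. Among the compounds with values here, no two measured compounds differ in only one place, so the data give no direct guide to this change. Compound 2 also carries chloro, but on a different core, so its 5250 nM cannot settle the question.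

A small change in this assay is therefore expected, probably not beyond the scatter. The estimated step is a 1.6-fold lower number from compound 1 to compound 4 (0.20 log units; within the scatter). For compound 4, the expected value is 35000 nM, within an estimated range of 11000 nM to 100000 nM.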

Compound 4, half-maximal inhibitory concentration: 16600 nM
Compound 4: middle estimate off by 2.1-fold (0.32 log units), on the high side, and the stated range covers the measured number.
By their numbers in this assay, from the lowest: compound 2; then compound 4; then compounds 3 and 1 (each within the scatter of the next).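

Placing chloro in place of trifluoromethyl on an aromatic carbon, para to a large group, produces a 3.3-fold lower number from compound 1 to compound 4 (0.52 log units; beyond the scatter) in this assay on an otherwise unchanged structure. Within the data shown here, this is the first pair of measured compounds that differ in only one place, so it gives the first direct reading of this position. It shows that the group held there can shift the result beyond the scatter, and that of these two groups, chloro gives the stronger inhibitor. No measured information accompanies this result that could explain the step.

Among these compounds, with only two groups compared at this position, it remains open whether fluoro, methoxy or an amine there would give a lower or a higher number. Also open, going by these compounds, is whether this same exchange would give a step of similar size on a different core.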